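Second acetyl on the nitrogen of compound 2

A few compounds are considered here, and "the series" means these few. Any claim that something is new, unique, unknown or untested is made for them only; others in the source may bear on it.

Of the compounds shown here, three have numbers so far in a functional assay on K562 cells (Homo sapiens) for cytotoxicity, read by MTT assay, with a stated time of 48 h; a higher number here means a weaker inhibitor, a lower number a stronger inhibitor. Compound 1 `COc1ccc(-c2c(-c3cc(OC)c(OC)c(OC)c3)noc2N)cc1` gives 40 nM. Compound 2 `COc1ccc(-c2c(-c3cc(OC)c(OC)c(OC)c3)noc2NC(C)=O)cc1` gives 380 nM. Compound 3 `COc1ccc(-c2c(-c3cc(OC)c(OC)c(OC)c3)noc2NC(C)=O)cc1OC` gives 3710 nM. Compound 2 therefore holds the second highest of the three numbers, with compound 1 lower and compound 3 higher, both gaps beyond the scatter.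

Compound 4 `COc1ccc(-c2c(-c3cc(OC)c(OC)c(OC)c3)noc2N(C(C)=O)C(C)=O)cc1` is the next to be read. Its change from compound 2 is acetyl in place of hydrogen on an amide-type nitrogen, or acetamido to diacetylamino.

Within the data shown here, the closest precedent is the first acetyl on this nitrogen, a 9.5-fold higher number from compound 1 to compound 2 (0.98 log units; beyond the scatter). The other measured step, a 9.8-fold higher number from compound 2 to compound 3 (0.99 log units; beyond the scatter), is a methoxy in place of hydrogen on an aromatic carbon. It is a different kind of change and shows only how far the number can move from compound 2. Among the measured compounds shown here, no measured compound carries two acetyls on one nitrogen, so the direction rests on a single precedent. A further rise in this assay is expected, probably no larger than the first one. The expected move is a 2.6-fold higher number from compound 2 to compound 4 (0.42 log units; beyond the scatter). For compound 4 the estimate is 1000 nM, with an expected range of 250 nM to 4500 nM.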

Compound 4, half-maximal inhibitory concentration: 68 nM
The estimate for compound 4 lay 15-fold (1.17 log units) above the measured number, and the stated range ends above it.
By their numbers in this assay, from the lowest: compounds 1 and 4 (each within the scatter of the next); then compound 2; then compound 3.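

In this assay the effect of acetyl in place of hydrogen on this nitrogen is not fixed in direction: the first acetyl gives a 9.5-fold higher number from compound 1 to compound 2 (0.98 log units; beyond the scatter) and the second gives a 5.6-fold lower number from compound 2 to compound 4 (0.75 log units; beyond the scatter) on the amide-type nitrogen, so the first step does not predict the second. The diacetylamino compound also returns to the level of the free amine, with a 1.7-fold higher number from compound 1 to compound 4 (0.23 log units; within the scatter) as the step, so among compounds 1, 2 and 4 only the acetamido compound 2 stands apart, and a free hydrogen on this nitrogen does not separate compound 1 from compound 4. Nothing available explains this reversal.

The compounds shown leave open whether the reversal is specific to acetyl or also appears with a longer acyl chain such as propionyl, with a benzoyl group, or with a methanesulfonyl group on the same nitrogen. They also leave open whether diacetylamino recovers the number in the presence of the extra methoxy of compound 3, which carries only the acetamido group.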